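Homologation of an alkenyl side chain on a shared core

This account rests on a few compounds, and the source may have more. Where it says the series, first, only, none or still open, it means among the compounds named here.

Measured compounds:
compound 1, `CCCC(=O)c1c(C)nn(CCCN2CCN(c3ccc(C)cc3)CC2)c(=O)c1N`: 0%
compound 2, `CCCCC(=O)c1c(C)nn(CCCN2CCN(c3ccc(C)cc3)CC2)c(=O)c1N`: 8%
compound 3, `C/C=C/c1c(C)nn(CCCN2CCN(c3ccc(C)cc3)CC2)c(=O)c1N`: 0%

Of the compounds shown here, three on a shared core have been measured in a functional assay on the whole organism (Abdomen, strain Swiss) for inhibition, with Mus musculus as the target, with stated times of 30 min, 10 min and 5 min, at a dose of 10 mg/kg by the oral route; on this read-out higher numbers stand for a stronger effect at the one dose given and lower numbers for a weaker effect. Compound 1 gives 0%, compound 2 gives 8% and compound 3 gives 0%. Compound 1 and compound 2 differ by methyl in place of hydrogen on a saturated chain carbon, three bonds along the chain from a carbonyl carbon, and the step is a number 8 percentage points higher from compound 1 to compound 2 (within the scatter). Compound 1 and compound 3 differ in their side chain by prop-1-en-1-yl in place of propylcarbonyl on an aromatic carbon, with no change at the digits printed from compound 1 to compound 3 (within the scatter).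

Compound 4, `CC/C=C/c1c(C)nn(CCCN2CCN(c3ccc(C)cc3)CC2)c(=O)c1N`, has not yet been measured in this assay. It differs from compound 3 by methyl in place of hydrogen on a saturated chain carbon bound to a double-bonded chain carbon. This is the same kind of change as from compound 1 to compound 2, but not the same: there the methyl entered on a saturated chain carbon, three bonds along the chain from a carbonyl carbon, while here it enters on a saturated chain carbon bound to a double-bonded chain carbon.

The step from compound 3 to compound 4 is expected to be a number 5 percentage points higher from compound 3 to compound 4 (within the scatter), resting on compound 1 and compound 2, whose step is a number 8 percentage points higher from compound 1 to compound 2 (within the scatter), and on compound 3 with its value of 0%. For compound 4 the estimate is 5%, between 0% and 20%.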

Compound 4, a percentage reported as inhibition, in the whole organism at one dose (the size of the read-out at that dose, not a potency): 5%
Estimate against measurement, compound 4: no gap at the digits printed; the measured number falls inside the stated range.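

In this assay the added methyl gives a number 5 percentage points higher from compound 3 to compound 4 (within the scatter), while replacing the carbonyl side chains by but-1-en-1-yl gives a number 3 percentage points lower from compound 2 to compound 4 (within the scatter) and a number 5 percentage points higher from compound 1 to compound 4 (within the scatter). Set side by side, the methyl change reads alike on the two cores: the same change on two cores in this assay, a number 8 percentage points higher (within the scatter) from compound 1 to compound 2 and a number 5 percentage points higher (within the scatter) from compound 3 to compound 4, 3 percentage points apart, within the scatter of two such steps. This shows that the change behaves no differently on the alkenyl core than on the carbonyl core within this small set, but it does not show that the methyl has a real effect on either core, since neither step clears the scatter.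

The compounds shown leave open whether a longer chain, an amine or a carboxylic acid on that same aromatic carbon would give a step beyond the scatter in this assay. They also leave open whether the methyl change would read alike on the two cores at another dose, where a larger effect might make a comparison more telling.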